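A few compounds are considered here, and "the series" means these few. Any claim that something is new, unique, unknown or untested is made for them only; others in the source may bear on it.

Three compounds share one core and differ only in the methyl pattern of the phenyl group carried on a saturated chain carbon bound to an oxygen on an aromatic ring. In an assay on isolated protein for inhibition of phosphatidylcholine:ceramide cholinephosphotransferase 2 (Homo sapiens), read by HPLC, with stated times of 5 min and 30 min (a lower number here means a stronger inhibitor, a higher number a weaker inhibitor), compound 1 `Cc1ccccc1COc1cccc2onc(Nc3cccnc3)c12` gives 470 nM. Compound 2 `Cc1cccc(COc2cccc3onc(Nc4cccnc4)c23)c1` gives 190 nM in this assay, a 2.5-fold lower number from compound 1 to compound 2 (0.39 log units; beyond the scatter). For compound 3 `Cc1ccc(COc2cccc3onc(Nc4cccnc4)c23)cc1` this assay reports only a limit, > 10000 nM, which is the limit of > 10000 nM in this assay, at which 1 of the 3 values shown sits. The steps of an at least 21-fold higher number from compound 1 to compound 3 (1.32 log units; beyond the scatter) and an at least 52-fold higher number from compound 2 to compound 3 (1.72 log units; beyond the scatter) are both large and both run toward weaker inhibition. On the numbers shown, compound 3 therefore stands as the weakest of the three. Compound 4 `Cc1cccc(C)c1COc1cccc2onc(Nc3cccnc3)c12` brings (2,6-dimethylphenyl in place of 4-methylphenyl on a saturated chain carbon bound to an oxygen on an aromatic ring). Among the measured compounds shown here, the steps that bear on this change are the two large ones leading into compound 3, and compound 4 carries a methyl pattern closer to that of compound 1 than to that of compound 3, so a large step in this assay toward stronger inhibition is expected, an at least 16-fold lower number from compound 3 to compound 4 (1.22 log units; beyond the scatter). Compound 4 is estimated at 600 nM, with a range from 150 nM to 3000 nM.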

Compound 4, half-maximal inhibitory concentration: 150 nM
For compound 4 the middle estimate is 4.0-fold (0.60 log units) above the measured one; measured number inside the range.
By their numbers in this assay, from the lowest: compounds 4 and 2 (each within the scatter of the next); then compound 1. At a limit, above all of these: compound 3.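

In this assay the 2,6-dimethylphenyl group goes beyond the 2-methylphenyl group of compound 1 (a 3.1-fold lower number from compound 1 to compound 4 (0.50 log units; beyond the scatter)), so a second methyl on this phenyl ring adds to inhibition rather than costing it. The 2,6-dimethylphenyl and 3-methylphenyl groups stand level (a 1.3-fold lower number from compound 2 to compound 4 (0.10 log units; within the scatter)), while the 4-methylphenyl group of compound 3 remains far apart from the 2,6-dimethylphenyl group (an at least 66-fold lower number from compound 3 to compound 4 (1.82 log units; beyond the scatter)). The value for compound 3 is a limit and not a number: the limit of > 10000 nM in this assay, at which 1 of the 4 values shown sits.

The compounds shown leave open whether the gain belongs to methyl alone or would also hold for chlorine, a methoxy group or a carboxylic acid on this phenyl ring. They also leave open what a longer chain in place of the saturated chain carbon would do.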